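Swapping an Anilino Group for a Lactam: Solubility Outlook

A few compounds are considered here, and "the series" means these few. Any claim that something is new, unique, unknown or untested is made for them only; others in the source may bear on it.

Measured compounds:
compound 1, `Fc1ccc2c(c1CNc1ncc(Oc3ccccc3)c3nncn13)CCO2`, 8000 nM
compound 2, `CN(c1cccnc1)c1cnc(NCc2c(F)ccc3c2CCO3)n2cnnc12`, 47000 nM
compound 3, `Fc1ccc2c(c1CNc1ncc(Nc3ccccc3)c3nncn13)CCO2`, 3000 nM

In a physicochemical assay for solubility, read by LC-MS, in phosphate buffer, with a stated time of 24 h, at pH 7.4 (a higher number here means a more soluble compound, a lower number a less soluble compound), compound 3 gives the lowest of the three numbers, with compound 1 nearest and compound 2 furthest. The unmeasured compound 4, `C[C@@H]1CC(=O)N(c2cnc(NCc3c(F)ccc4c3CCO4)n3cnnc23)C1`, differs from compound 3 by 4-methyl-2-oxopyrrolidin-1-yl in place of anilino on an aromatic carbon. Among the measured compounds shown here, two measured steps bear on this position: a 2.7-fold lower number from compound 1 to compound 3 (0.43 log units; beyond the scatter) and a 16-fold lower number from compound 2 to compound 3 (1.19 log units; beyond the scatter), both beyond the scatter, showing that the anilino compound sits lowest among the groups tried there. Since the entering group is a five-membered non-aromatic ring rather than an aromatic ring, compound 4 is expected to move upward, with a 10-fold higher number from compound 3 to compound 4 (1.00 log units; beyond the scatter). Compound 4 is therefore estimated at 30000 nM, within a range of 8000 nM to 110000 nM.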

Compound 4, solubility: 130000 nM
Compound 4: the middle estimate sits 4.3-fold (0.64 log units) below what was measured, outside the stated range (above it).
By their numbers in this assay, from the lowest: compound 3; then compound 1; then compound 2; then compound 4.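

In this assay, 4-methyl-2-oxopyrrolidin-1-yl gives the highest number yet at this position, with a 43-fold higher number from compound 3 to compound 4 (1.64 log units; beyond the scatter), a 16-fold higher number from compound 1 to compound 4 (1.21 log units; beyond the scatter) and a 2.8-fold higher number from compound 2 to compound 4 (0.44 log units; beyond the scatter). Compounds 1, 2 and 3 each carry a six-membered aromatic ring in the group at this position, so compound 4 shows that a five-membered non-aromatic ring can stand there and exceed all three. Nothing available accounts for the size of these steps. The compounds shown leave open what the methyl group and its defined stereocentre contribute. They also leave open how the unmethylated pyrrolidin-2-one, a morpholine or an open-chain amide would compare.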